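Solubility notes: pyridinyl ether variation on the shared core

The source may report more compounds than this note shows. Statements on the series, on what has been measured and on what is new or still open speak of the compounds shown alone.

The series is followed in a physicochemical assay for solubility, read by HPLC, measured as thermodynamic solubility, with a stated time of 4 h, at pH 6.8; a higher number here means a more soluble compound, a lower number a less soluble compound. Compound 2 `Cn1c(COc2cccc(C(=O)O)c2)nc2ccc(Oc3ccc(Cl)cn3)cc21` gives 17 ug/mL, the higher of the two measured numbers. Compound 1 `Cn1c(COc2cccc(C(=O)O)c2)nc2ccc(Oc3ccc4c(c3)CCC4)nc21` gives 4.3 ug/mL, a lower number, and the gap between compound 1 and compound 2 lies beyond the scatter of the measurement. Among the measured compounds shown here, no pair of measured compounds differs in only one place, so no single step is available to calibrate the next change.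

Compound 3 `Cc1ccc(C)c(Oc2ccc3nc(COc4cccc(C(=O)O)c4)n(C)c3c2)n1` is not yet measured. Relative to compound 2 the change is 3,6-dimethylpyridin-2-yl in place of 5-chloropyridin-2-yl on an oxygen on an aromatic ring. Nothing in the measured pair isolates this exchange on the oxygen, so the expectation rests on compound 2 alone. The step of a 1.5-fold lower number from compound 2 to compound 3 (0.19 log units; within the scatter) is expected to be small and downward, not clearly beyond the scatter. Compound 3 is thus estimated at about 11 ug/mL, with a plausible range from 4 ug/mL to 30 ug/mL.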

Compound 3, solubility: 85 ug/mL
Estimate against measurement, compound 3: 7.7-fold (0.89 log units) below; the whole stated range lies below it.
By their numbers in this assay, from the lowest: compound 1; then compound 2; then compound 3.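

In this assay, among the compounds shown here, the exchange of 5-chloropyridin-2-yl for 3,6-dimethylpyridin-2-yl on an oxygen on an aromatic ring gives a 5.0-fold higher number from compound 2 to compound 3 (0.70 log units; beyond the scatter) and is the first step that differs in one place. The group on this oxygen is therefore a place where the read-out can move beyond the scatter, even though both groups hold one six-membered aromatic ring with 1 hetero atom and no net charge. No measurement shown here accounts for the size or direction of this step.

From the compounds shown here alone, it remains open which part of the exchange carries the step: the loss of the chlorine or either of the two methyl groups. Also open, going by these compounds, is how a pyridin-2-yl group bearing an amine or a methoxy group would read in this assay on the same shared core.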